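Bromo on the pendant phenyl of the dicinnamoyl series

A few compounds are considered here, and "the series" means these few. Any claim that something is new, unique, unknown or untested is made for them only; others in the source may bear on it.

Measured in a functional assay on HeLa cells (Homo sapiens) for cytotoxicity, read by MTT assay, with a stated time of 24 h; a lower number here means a stronger inhibitor, a higher number a weaker inhibitor:
compound 1 `Cc1cc(O)c(C(=O)/C=C/c2ccccc2Cl)c(-c2ccccc2)c1C(=O)/C=C/c1ccccc1Cl`: "not active" (no number reported)
compound 2 `Cc1cc(O)c(C(=O)/C=C/c2ccc(OCc3ccccc3)cc2)c(-c2ccccc2)c1C(=O)/C=C/c1ccc(OCc2ccccc2)cc1`: 20000 nM
compound 3 `Cc1cc(O)c(C(=O)/C=C/c2ccccc2)c(-c2ccc(Br)cc2)c1C(=O)/C=C/c1ccccc1`: 30000 nM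

Compound 2 and compound 3 give numbers that lie within the scatter of each other, so no order between them is claimed; compound 1 is reported without a number. Compound 4 `Cc1cc(O)c(C(=O)/C=C/c2ccc(OCc3ccccc3)cc2)c(-c2ccc(Br)cc2)c1C(=O)/C=C/c1ccc(OCc2ccccc2)cc1` is not yet measured. It differs from compound 2 by bromo in place of hydrogen on an aromatic carbon, the same change that separates the core of compound 3 from that of compound 2, although the cinnamoyl ends differ there too. Among the measured compounds shown here, no single step between measured compounds covers this change, so a step from compound 2 to compound 4 beyond the scatter is not expected in either direction. Compound 4 is estimated at 20000 nM, range 9000 nM to 45000 nM, which means an expected step of no change at the digits printed from compound 2 to compound 4 (within the scatter).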

Compound 4, half-maximal inhibitory concentration: "not active" (no number reported)
Compound 4: no number reported; no gap can be computed for the estimate.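

In this assay, among the compounds shown here, compound 4 gives "not active" (no number reported) and so no step from compound 2 to compound 4 can be read; no measured evidence bears on this result. From the compounds shown here alone, what phenyl to 4-bromophenyl does to the number on this core remains open.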